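Hydrazone aryl variation on a shared aryloxy-pyridine core

This account rests on a few compounds, and the source may have more. Where it says the series, first, only, none or still open, it means among the compounds named here.

Measured compounds and their values:
compound 1 `CN(C)CCn1cnnc1-c1cc(Oc2ccc(NC(=O)N/N=C/c3c(Cl)cccc3Cl)cc2F)ccn1` 350 nM
compound 2 `CN(C)CCn1cnnc1-c1cc(Oc2ccc(NC(=O)N/N=C/c3ccc(O)c(Br)c3)cc2F)ccn1` 430 nM
compound 3 `CN(C)CCn1cnnc1-c1cc(Oc2ccc(NC(=O)N/N=C/c3c(O)ccc4ccccc34)cc2F)ccn1` 890 nM

In a functional assay on NCI-H460 cells (Homo sapiens) for cytotoxicity, read by MTT assay, with a stated time of 72 h (a higher number here means a weaker inhibitor, a lower number a stronger inhibitor), compound 1 gives the lowest number of the three. Compound 2 lies nearest to it, a 1.2-fold higher number from compound 1 to compound 2 (0.09 log units; within the scatter), so the two cannot be ranked. Compound 3 is furthest off: a 2.5-fold higher number from compound 1 to compound 3 (0.41 log units; beyond the scatter), and against compound 2 the gap is a 2.1-fold higher number from compound 2 to compound 3 (0.32 log units; beyond the scatter).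

Compound 4 `CN(C)CCn1cnnc1-c1cc(Oc2ccc(NC(=O)N/N=C/c3ccc(O)cc3)cc2F)ccn1` has not yet been measured. It differs from compound 1 in one place:
4-hydroxyphenyl in place of 2,6-dichlorophenyl on a carbon with a double bond to nitrogen

Among the compounds with values here, the step that bears most on this is the one from compound 1 to compound 2, where a hydroxyphenyl bearing a bromine took the place of the dichlorophenyl and the change stayed within the scatter. Within the data shown here, compound 4 carries the same hydroxyphenyl without the bromine, and no measured pair shows what removing that halogen does. The step to compound 3 shows that a larger hydroxylated aryl gave a modest weakening. On balance a small to modest rise in the number is expected, not clearly beyond the scatter: a 1.7-fold higher number from compound 1 to compound 4 (0.23 log units; within the scatter). The estimate for compound 4 in this assay is 600 nM, with a range from 250 nM to 1500 nM.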

Compound 4, half-maximal inhibitory concentration: 1780 nM
Compound 4: the middle estimate sits 3.0-fold (0.47 log units) below what was measured; measured number outside the range, above it.
By their numbers in this assay, from the lowest: compounds 1 and 2 (each within the scatter of the next); then compounds 3 and 4 (each within the scatter of the next).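

The bromine now has a measured effect at this aryl position: in this assay, hydrogen in place of bromo gives a 4.1-fold higher number from compound 2 to compound 4 (0.62 log units; beyond the scatter). A hydroxyphenyl is therefore not equivalent to the 2,6-dichlorophenyl in its own right, as the replacement by 4-hydroxyphenyl gives a 5.1-fold higher number from compound 1 to compound 4 (0.71 log units; beyond the scatter), whereas compound 2, which carries both the hydroxyl and the bromine, could not be ranked against compound 1. Compound 4 also cannot be ranked against compound 3, with a 2.0-fold higher number from compound 3 to compound 4 (0.30 log units; within the scatter), so in this set of four the bromine separates the two hydroxylated aryl groups that stay level with or apart from compound 1 only in the case of compound 2, and neither compound 3 nor compound 4 matches it. Nothing shown here gives a reason for the change at this position.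

Still open, on these data alone, is whether a chlorine or a methyl in place of the bromine would serve as well, and whether a methoxy group in place of the hydroxyl would alter the result. An unsubstituted phenyl or a phenyl bearing a single chlorine would show how much of the value of compound 1 rests on each of its two halogens.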